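This account rests on a few compounds, and the source may have more. Where it says the series, first, only, none or still open, it means among the compounds named here.

Measured compounds:
compound 1 `Fc1ccccc1NC(=S)N/N=C/c1ccc2ccccc2n1` — > 100000 nM
compound 2 `NC(=S)N/N=C/c1cnc2ccccc2n1` — > 100000 nM
compound 3 `Cc1ccc(NC(=O)N/N=C/c2ccc3ccccc3n2)cc1` — > 100000 nM

In a functional assay on HL-60 cells (Homo sapiens) for antiproliferative activity, read by sulforhodamine B assay, with a stated time of 72 h (on this read-out lower numbers stand for stronger inhibition and higher numbers for weaker inhibition), compound 1 gives > 100000 nM, which is a limit of the assay and not a number. Compound 2 likewise gives > 100000 nM, a limit. Compound 3 gives > 100000 nM, again a limit. Every value shown sits at the limit of > 100000 nM in this assay, at which 3 of the 3 values shown sit, so compound 1 stands level with the others and no order among the three can be read.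

Compound 4 `Cc1ccccc1NC(=S)N/N=C/c1ccc2ccccc2n1` has not been measured in this assay. It differs from compound 1 by methyl in place of fluoro on an aromatic carbon. For the measured compounds named here, with no step between measured compounds available, the step from compound 1 to compound 4 is expected to be a step that the limit leaves unreadable from compound 1 to compound 4, none beyond the scatter. Compound 4 is therefore estimated at 150000 nM, in the range 50000 nM to 500000 nM, most likely reported only as a limit.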

Compound 4, half-maximal inhibitory concentration: 73200 nM
The estimate for compound 4 lay 2.0-fold (0.31 log units) above the measured number; the measured number falls inside the stated range.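

In this assay, for the compounds shown here, the change to 2-methylphenyl gives the only value shown that is a number, and it reads as an at least 1.3-fold lower number from compound 1 to compound 4 (0.13 log units; that floor lies within the scatter). Compound 1 gives > 100000 nM, which is a limit. From the compounds shown here alone, the methyl on this aromatic carbon can thus be placed on the scale, but the true size of the step stays unknown, and its floor alone shows no gain over fluoro.

Going by these compounds, whether an amine or a methoxy group on this same carbon would give a lower number remains open. No order can be read among the other compounds: the limit of > 100000 nM in this assay, at which 3 of the 4 values shown sit.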